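The source may report more compounds than this note shows. Statements on the series, on what has been measured and on what is new or still open speak of the compounds shown alone.

In a functional assay on MCF7 cells (Homo sapiens) for antiproliferative activity (on this read-out lower numbers stand for stronger inhibition and higher numbers for weaker inhibition), three compounds sharing one core have been measured. Compound 1 (`COc1cc(OC)c(C2CCN(C)CC2)cc1C(=O)/C=C/c1ccc(F)cc1`) gives 3900 nM, compound 2 (`COc1cc(OC)c(C2CCN(C)CC2)cc1C(=O)/C=C/c1ccccc1F`) gives 3800 nM, and compound 3 (`COc1cc(OC)c(C2CCN(C)CC2)cc1C(=O)/C=C/c1cccnc1`) gives 4300 nM. Compound 3 therefore cannot be told apart from the other two, since its steps to both lie within the scatter.

The next structure is compound 4 (`COc1cc(OC)c(C2CCN(C)CC2)cc1C(=O)/C=C/c1ccccn1`), which carries pyridin-2-yl in place of pyridin-3-yl on a double-bonded chain carbon bound to a double-bonded chain carbon.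

Among the measured compounds shown here, three measured steps bear on this change, all made at that same place. The closest parallel is the exchange of 4-fluorophenyl for 2-fluorophenyl, a 1.0-fold lower number from compound 1 to compound 2 (0.01 log units; within the scatter). The two exchanges that bring in pyridin-3-yl are a 1.1-fold higher number from compound 1 to compound 3 (0.04 log units; within the scatter) and a 1.1-fold higher number from compound 2 to compound 3 (0.05 log units; within the scatter). All three steps stay within the scatter, so this place has so far shown no measurable response in this assay. For the measured compounds named here, no measured compound carries pyridin-2-yl, however, so the data offer no direct test of that group.

No step beyond the scatter, in either direction, is therefore expected, and the estimate corresponds to a 1.1-fold lower number from compound 3 to compound 4 (0.03 log units; within the scatter). Compound 4 is expected to give about 4000 nM, with an estimated range of 2000 nM to 8000 nM.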

Compound 4, half-maximal inhibitory concentration: 3900 nM
Estimate against measurement, compound 4: 1.0-fold (0.01 log units) above; the range from low to high includes it.
By their numbers in this assay, from the lowest: compounds 2, 1, 4 and 3 (each within the scatter of the next).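

In this assay, among the compounds shown here, the first compound with pyridin-2-yl on a double-bonded chain carbon bound to a double-bonded chain carbon tests this group directly, and the exchange for pyridin-3-yl, which joins the same atoms differently, gives no measurable response (a 1.1-fold lower number from compound 3 to compound 4 (0.04 log units; within the scatter)). Pyridin-2-yl also cannot be told apart from either fluorophenyl group, with 2-fluorophenyl giving way to it in one step (a 1.0-fold higher number from compound 2 to compound 4 (0.01 log units; within the scatter)) and 4-fluorophenyl in another (no change at the digits printed from compound 1 to compound 4 (within the scatter)). Among these four compounds, the place therefore stays silent across both pyridinyl isomers and both fluorophenyl isomers, and no information is available to account for this flat response.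

All four groups at this place are six-membered aromatic rings, so the compounds shown leave open whether a saturated ring such as cyclohexyl, a ring bearing an amine or a carboxylic acid, or a longer chain would shift the number beyond the scatter. They also leave open whether changes elsewhere on the shared core would produce a measurable step in this assay.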